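The source may report more compounds than this note shows. Statements on the series, on what has been measured and on what is new or still open speak of the compounds shown alone.

Compound 1 `CCCC(O)CC(=O)O[C@H](CC=C(C)C)C1=CC(=O)c2c(O)ccc(O)c2C1=O`: > 100000 nM, a limit of the assay
Compound 2 `CC(C)=CC[C@@H](OCC(C)O)C1=CC(=O)c2c(O)ccc(O)c2C1=O`: 16100 nM

Among the measured compounds shown here, compound 2 holds the only true number in a functional assay on DU-145 cells (Homo sapiens) for cytotoxicity, read by MTT assay; a lower number here means a stronger inhibitor, a higher number a weaker inhibitor. The result for compound 1 is a limit. Compound 3 `CC[C@@](C)(O)CC(=O)O[C@H](CC=C(C)C)C1=CC(=O)c2c(O)ccc(O)c2C1=O` has (2-hydroxy-2-methylbutyl)carbonyl in place of 2-hydroxypropyl on an oxygen on a saturated carbon. For the measured compounds named here, one measured step bears on this, an at least 6.2-fold lower number from compound 1 to compound 2 (0.79 log units; beyond the scatter), in which 2-hydroxypropyl replaced (2-hydroxypentyl)carbonyl. The new change runs the opposite way, so a step of similar size towards a weaker result is expected, an estimated 3.7-fold higher number from compound 2 to compound 3 (0.57 log units; beyond the scatter). The expected value for compound 3 is 60000 nM, with an estimated range from 20000 nM to 100000 nM.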

Compound 3, half-maximal inhibitory concentration: 12700 nM
Beside the measured number, compound 3's estimate is 4.7-fold (0.67 log units) above it; measured number below the stated range.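

Replacing 2-hydroxypropyl with (2-hydroxy-2-methylbutyl)carbonyl on this oxygen makes no change beyond the scatter (a 1.3-fold lower number from compound 2 to compound 3 (0.10 log units; within the scatter)), so a carbonyl at this place does not by itself give a weak result. The two esters differ at the chain end, where 1-hydroxy-1-methylpropyl in place of 1-hydroxybutyl gives a clear gain (an at least 7.8-fold lower number from compound 1 to compound 3 (0.89 log units; beyond the scatter)). From the compounds shown here alone, the true size of that gain stays unknown because compound 1 has only a limit: the limit of > 100000 nM in this assay, at which 1 of the 3 values shown sits. Going by these compounds, whether an amine, a carboxylic acid or a longer chain at this end would fit equally well remains open.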